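The compounds below may be only part of what the source reports. "The series", "measured", "known", "first", "only" and "open" are said of these compounds alone.

Measured compounds:
compound 1 `NS(=O)(=O)NCCC1CCN(c2cc(-c3ccccc3)ncn2)CC1` — 66500 nM in a functional assay on HT-29 cells (Homo sapiens) for antiproliferative activity, read by sulforhodamine B assay, with a stated time of 48 h; a higher number here means a weaker inhibitor of growth, a lower number a stronger inhibitor of growth
compound 2 `Cc1ccc(-c2cc(N3CCC(CCNS(N)(=O)=O)CC3)ncn2)cc1` — 52300 nM
compound 3 `CC(C)(C)c1ccc(-c2cc(N3CCC(CCNS(N)(=O)=O)CC3)ncn2)cc1` — 10300 nM

Compound 2 stands second highest of the three numbers; its nearest neighbour is compound 1, at a 1.3-fold lower number from compound 1 to compound 2 (0.10 log units; within the scatter), and its furthest is compound 3, at a 5.1-fold lower number from compound 2 to compound 3 (0.71 log units; beyond the scatter). Compound 4 `NS(=O)(=O)NCCC1CCN(c2cc(-c3cccc(Cl)c3)ncn2)CC1` is not yet measured. It differs from compound 2 by 3-chlorophenyl in place of 4-methylphenyl on an aromatic carbon. Within the data shown here, no measured step covers this change. The two known steps show that adding a methyl to the shared core's aryl group, a 1.3-fold lower number from compound 1 to compound 2 (0.10 log units; within the scatter), stayed within the scatter, while tert-butyl gave only a modest shift, a 6.5-fold lower number from compound 1 to compound 3 (0.81 log units; beyond the scatter). A swap of one small group for another is therefore expected to give a 1.2-fold lower number from compound 2 to compound 4 (0.07 log units; within the scatter), not beyond the scatter. Compound 4 is estimated at 45000 nM, in a range from 20000 nM to 100000 nM.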

Compound 4, concentration for 50% growth inhibition: 31600 nM
Estimate against measurement, compound 4: 1.4-fold (0.15 log units) above; measured number inside the range.
By their numbers in this assay, from the lowest: compound 3; then compounds 4, 2 and 1 (each within the scatter of the next, the first and the last beyond it).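

In this assay, 3-chlorophenyl in place of 4-methylphenyl gives a 1.7-fold lower number from compound 2 to compound 4 (0.22 log units; within the scatter), so this exchange of one substituted phenyl for another stays within the scatter. Chloro in place of hydrogen on the phenyl of compound 1 gives a 2.1-fold lower number from compound 1 to compound 4 (0.32 log units; beyond the scatter), a modest step just beyond the scatter, which shows that a single chlorine can shift this number. Nothing given here accounts for either step. Going by these compounds, whether a methoxy group or an amine in place of the chloro would shift the number further remains open.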